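A few compounds are considered here, and "the series" means these few. Any claim that something is new, unique, unknown or untested is made for them only; others in the source may bear on it.

Compound 1 `Cc1cc(NC(=O)CN2CCC(OCc3ccc(F)c(F)c3)CC2)ccc1F` and compound 2 `Cc1cc(NC(=O)CN2CCC3(CCCN3Cc3ccc(F)c(F)c3)C2)ccc1F` carry the same 4-fluoro-3-methylphenyl group on an amide-type nitrogen but are built on different cores; the difference between the two cores is not broken down here. In an assay on membranes from HEK293 cells for displacement of a labelled ligand from Sigma intracellular receptor 2 (Homo sapiens) (a lower number here means a stronger inhibitor, a higher number a weaker inhibitor), compound 1 gives 123 nM, while compound 2 gives 47 nM. Compound 1 therefore has the highest number of the three measured compounds, and its gap to compound 2 lies beyond the scatter.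

Compound 3 `Cc1c(Cl)cccc1NC(=O)CN1CCC2(CCCN2Cc2ccc(F)c(F)c2)C1` differs from compound 2 in a single place: 3-chloro-2-methylphenyl in place of 4-fluoro-3-methylphenyl on an amide-type nitrogen. In this assay compound 3 gives 43 nM, so the step of a 1.1-fold lower number from compound 2 to compound 3 (0.04 log units; within the scatter) stays within the scatter, meaning the swap of aryl groups made no real difference on the core of compound 2.

Compound 4 `Cc1c(Cl)cccc1NC(=O)CN1CCC(OCc2ccc(F)c(F)c2)CC1` has not yet been measured. It differs from compound 1 in exactly the same way: 3-chloro-2-methylphenyl in place of 4-fluoro-3-methylphenyl on an amide-type nitrogen. The place is the same word for word, on an amide-type nitrogen whose other neighbour is a carbonyl carbon, so this is the same change carried over onto the core of compound 1. The expectation for compound 4 is a step of about a 1.1-fold lower number from compound 1 to compound 4 (0.05 log units; within the scatter), resting on the earlier result because a 1.1-fold lower number from compound 2 to compound 3 (0.04 log units; within the scatter) was within the scatter. On that basis compound 4 is estimated at 110 nM, with a likely range from 55 nM to 220 nM.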

Compound 4, inhibition constant: 299 nM
For compound 4 the middle estimate is 2.7-fold (0.43 log units) below the measured one; the whole stated range lies below it.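

In this assay, swapping the aryl group on the core of compound 1 gives a 2.4-fold higher number from compound 1 to compound 4 (0.39 log units; beyond the scatter), so on this core alone the change has a real effect on the number. Yet a difference between the two cores cannot be claimed, since the new step cannot be told apart from the earlier one, even though only the new step lies beyond the scatter when each is read alone: the same change on two cores in this assay, a 1.1-fold lower number (0.04 log units; within the scatter) from compound 2 to compound 3 and a 2.4-fold higher number (0.39 log units; beyond the scatter) from compound 1 to compound 4, 2.7-fold (0.42 log units) apart, within the scatter of two such steps

This does not show that the core alters what the swap does, and it does not prove that the change carries over unchanged either; a single pair on each core cannot separate a true dependence on the core from ordinary spread in the measurements.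

The compounds shown leave open which part of the change matters, since the chlorine, the fluorine and the placing of the methyl all differ at once between 3-chloro-2-methylphenyl and 4-fluoro-3-methylphenyl. They also leave open how the step would behave with a plain phenyl, or with a phenyl bearing a methoxy group or a nitrile, on either core.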